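Adding 2-methoxyethyl to compound 3

The source may hold more compounds than are shown below. What is called first, only, known or untested is meant among the compounds shown, and "the series" means these compounds.

Three compounds have been measured in a functional assay on RAW264.7 cells (Mus musculus) for inhibition, read by Griess assay, with stated times of 1 h and 24 h (on this read-out lower numbers stand for stronger inhibition and higher numbers for weaker inhibition), so far:

- compound 1 `O=C1OC(Cc2nc(Cc3ccccc3)no2)c2ccccc21` gives > 10000 nM as a limit
- compound 2 `O=C1OC(Cc2nc(-c3ccc(Oc4ccccc4)cc3)no2)c2ccccc21` gives > 10000 nM as a limit
- compound 3 `COc1ccc(C(O)C2OC(=O)c3c(OC)cc(OC)cc32)cc1` gives > 10000 nM as a limit

None of these three results is a number; each is only a limit of the assay. Compound 3 stands at the limit of > 10000 nM in this assay, at which 3 of the 3 values shown sit, and therefore offers no exact starting point.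

Compound 4 `COCCCOc1ccc(C(O)C2OC(=O)c3c(OC)cc(OC)cc32)cc1` differs from compound 3 by a single change: 2-methoxyethyl in place of hydrogen on a saturated chain carbon bound to an oxygen on an aromatic ring. The same difference reads as methoxy to 3-methoxypropoxy. Among the measured compounds shown here, no measured pair of compounds shows what such a change does, so the expectation is loose. A modest step towards stronger inhibition in this assay is expected, and the result may again be only a limit. The expected change is an at least 1.2-fold lower number from compound 3 to compound 4 (0.09 log units; that floor lies within the scatter) on this estimate. In this assay the estimate for compound 4 is 8000 nM (expected range 2000 nM to 30000 nM).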

Compound 4, half-maximal inhibitory concentration: 1260 nM
Beside the measured number, compound 4's estimate is 6.3-fold (0.80 log units) above it; the whole stated range lies above it.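

In this assay, the change from methoxy to 3-methoxypropoxy gives an at least 7.9-fold lower number from compound 3 to compound 4 (0.89 log units; beyond the scatter). This is the only step among the compounds shown, and it shows that this position, on the oxygen on an aromatic ring, can carry a change that moves the read-out beyond the scatter. Because compound 3 gives only a limit, the true size of the step remains unknown, and compound 4 is the only compound with an exact value: the limit of > 10000 nM in this assay, at which 3 of the 4 values shown sit.

The compounds shown leave open whether the gain needs the whole 3-methoxypropoxy group, or whether a plain propyl chain, a longer chain or an amine at the chain end would serve as well. They also leave open whether the same group would have any such effect on the core of compound 1 or compound 2.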